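The compounds below may be only part of what the source reports. "The series", "measured", "known", "first", "only" and "open" are said of these compounds alone.

Compound 2, `Cc1cccc(OC[C@@H]2[C@H]3CC[C@H](c4nc(C(=O)O)cs4)O[C@H]3C[C@H]2O)c1`, gives 3.6 nM in a functional assay on CHO cells for agonist activity at prostaglandin E2 receptor EP2 subtype (Homo sapiens), read by HTRF and cAMP accumulation, with a stated time of 30 min; a higher number here means that more compound is needed for the effect, a lower number that less compound is needed. That places it at the low end of the three numbers seen so far: compound 3, `O=C(O)c1csc([C@H]2CC[C@@H]3[C@@H](/C=C/COc4ccccc4)[C@H](O)C[C@@H]3O2)n1`, gives 3.8 nM, which lies within the scatter of compound 2, whereas compound 1, `O=C(O)c1csc([C@H]2CC[C@@H]3[C@@H](CCCCCOc4ccccc4)[C@H](O)C[C@@H]3O2)n1`, gives 28 nM, a number that sits well above compound 2 and beyond the scatter. Compound 4, `O=C(O)c1csc([C@H]2CC[C@@H]3[C@@H](COc4ccccc4C(F)(F)F)[C@H](O)C[C@@H]3O2)n1`, has not yet been measured in this assay. The change from compound 2 to compound 4 is 2-(trifluoromethyl)phenyl in place of 3-methylphenyl on an oxygen on a saturated carbon. Among the compounds with values here, no measured pair in this set differs by a change of this kind, so there is no direct precedent for the size of the step. The account can only note that compound 2 and compound 3, which share an aryl ether reaching from the core, both give low numbers, while compound 1 gives a higher one. For compound 4 a modest step is expected, a 2.2-fold higher number from compound 2 to compound 4 (0.35 log units; beyond the scatter), towards a somewhat higher number, but one that could as well stay within the scatter of compound 2. The estimate for compound 4 in this assay is therefore 8 nM, with a range from 2 nM to 30 nM.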

Compound 4, half-maximal effective concentration: 0.5 nM
Compound 4: the middle estimate sits 16-fold (1.20 log units) above what was measured; the whole stated range lies above it.
By their numbers in this assay, from the lowest: compound 4; then compounds 2 and 3 (each within the scatter of the next); then compound 1.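

In this assay, the aryl group on this oxygen proves to be a place where the number can move well beyond the scatter: the exchange gives a 7.2-fold lower number from compound 2 to compound 4 (0.86 log units; beyond the scatter) as 2-(trifluoromethyl)phenyl replaces 3-methylphenyl. Within the data shown here, the earlier compounds included no pair differing in one place, so this is the first direct reading of a change here, and it shows that an aryl group of 10 heavy atoms in place of 7 can go with a lower number. Nothing available here explains the size or direction of this step.

The step changes both the substituent and its place on the ring, so 2-methylphenyl and 3-(trifluoromethyl)phenyl would be needed to separate the two. As far as these compounds go, whether 2-(trifluoromethyl)phenyl would give a similar step on the longer chains of compound 1 and compound 3 also stays open.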